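Shortening the Amide Side Chain of Compound 2

The source may hold more compounds than are shown below. What is called first, only, known or untested is meant among the compounds shown, and "the series" means these compounds.

Compound 2 `NC(=O)CCCCc1c[nH]c2ccc(F)cc12` is the weaker of the two compounds that gave a number in an assay on isolated protein (urine) for inhibition of Myeloperoxidase (Homo sapiens), with a stated time of 5 min (on this read-out lower numbers stand for stronger inhibition and higher numbers for weaker inhibition), where compound 2 gives 39 nM. Compound 1 `NCCCCc1c[nH]c2c(F)cccc12` gives 6 nM in this assay, a lower number and a step beyond the scatter. Compound 3 `NCCCc1c[nH]c2ccc(C(=O)O)cc12` is reported as "not active" (no number reported) in this assay, with no number attached. Compound 4 `NC(=O)CCCc1c[nH]c2ccc(F)cc12` has not yet been measured. It differs from compound 2 by one change: carbamoyl in place of carbamoylmethyl on a saturated chain carbon, three bonds along the chain from an aromatic carbon. Among the measured compounds shown here, no measured pair shows this change alone, so there is no direct guide, and compound 3 differs from compound 1 in more than one place, so it offers no clean comparison. A modest weakening is expected, a 1.5-fold higher number from compound 2 to compound 4 (0.19 log units; within the scatter), though a step within the scatter would not surprise. Compound 4 is thus expected to give 60 nM, within 15 nM to 250 nM.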

Compound 4, half-maximal inhibitory concentration: 18 nM
Compound 4: middle estimate off by 3.3-fold (0.52 log units), on the high side; the measured number falls inside the stated range.
By their numbers in this assay, from the lowest: compound 1; then compound 4; then compound 2.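

Replacing carbamoylmethyl with carbamoyl on a saturated chain carbon, three bonds along the chain from an aromatic carbon, gives a 2.2-fold lower number from compound 2 to compound 4 (0.34 log units; beyond the scatter) in this assay. Among the compounds shown here, this is the first comparison here that differs in only one place, and it shows that the length of the chain carrying the amide changes the read-out. Here the shorter chain gives the lower number, though the step is modest.

From the compounds shown here alone, whether a nitrile or a methyl ester in place of the carbamoyl would keep this level remains open. No measurement shown explains this step.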